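This account rests on a few compounds, and the source may have more. Where it says the series, first, only, none or still open, it means among the compounds named here.

Measured so far in a functional assay on MCF7 cells (Homo sapiens) for antiproliferative activity; on this read-out lower numbers stand for stronger inhibition and higher numbers for weaker inhibition:
- compound 1 (`CC(=O)Oc1ccc(C(=O)Nc2cc3ccc(OCC4CCCN(C)C4)c(C)c3oc2=O)cc1CC=C(C)C`) gives 1650 nM
- compound 2 (`CC(C)=CCc1cc(C(=O)Nc2cc3ccc(OCCCN4CCCC4)c(C)c3oc2=O)ccc1O`) gives 990 nM

Compound 2 at 990 nM stands within the scatter of compound 1 at 1650 nM, so these two numbers do not rank the pair. For the measured compounds named here, no step between measured compounds that differ in one place is available.

The next compound is compound 3 (`CC(C)=CCc1cc(C(=O)Nc2cc3ccc(OCCCN(C)C(C)C)c(C)c3oc2=O)ccc1O`), which departs from compound 2 in one place: isopropyl(methyl)amino in place of pyrrolidin-1-yl on a saturated chain carbon, three bonds along the chain from an oxygen on an aromatic ring. The exchange sits on a saturated chain carbon, three bonds along the chain from an oxygen on an aromatic ring, and 3-(pyrrolidin-1-yl)propyl becomes 3-(isopropyl(methyl)amino)propyl.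

Going by the values given here, no measured pair shows what this exchange does. The expectation therefore starts from compound 2 at 990 nM, and no step beyond the scatter is expected in this assay in either direction. The estimated change is a 1.1-fold higher number from compound 2 to compound 3 (0.05 log units; within the scatter) and no more than that is expected. Compound 3 is expected at 1100 nM with an estimated range from 450 nM to 2700 nM.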

Compound 3, half-maximal inhibitory concentration: 1050 nM
The estimate for compound 3 lay 1.0-fold (0.02 log units) above the measured number, and the stated range covers the measured number.
By their numbers in this assay, from the lowest: compounds 2, 3 and 1 (each within the scatter of the next).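

In this assay, isopropyl(methyl)amino in place of pyrrolidin-1-yl on a saturated chain carbon, three bonds along the chain from an oxygen on an aromatic ring, gives a 1.1-fold higher number from compound 2 to compound 3 (0.03 log units; within the scatter). Both groups count the same heavy atoms, and the five-membered non-aromatic ring is the main counted difference, so for this one pair, the ring can be given up at this position without a step beyond the scatter. No measurement at hand bears on why the two compounds read alike.

On these data alone, it remains open whether the tolerance seen here extends to amines of a different kind, such as morpholin-4-yl or an unsubstituted amino group, or to a carboxylic acid at the same chain end, and whether a longer chain than 3-(pyrrolidin-1-yl)propyl would hold the number in this assay. Compound 1 differs from compound 2 and compound 3 in more than one place, so the contribution of its side chain cannot be separated from its other change.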